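Chloro for Methyl on a Weakly Binding Core

The compounds below may be only part of what the source reports. "The series", "measured", "known", "first", "only" and "open" are said of these compounds alone.

Compound 1 `Fc1ccc(-c2noc3c2CCNCC3)cc1` and compound 2 `Cc1ccc(-c2n[nH]c3c2CCNCC3)cc1` were both examined in an assay on cells for displacement of a labelled ligand from 5-hydroxytryptamine receptor 4 (Homo sapiens), read by scintillation counting, with a stated time of 1.5 h; on this read-out lower numbers stand for stronger inhibition and higher numbers for weaker inhibition. Compound 1 gives > 10000 nM, which is a limit of the assay rather than a number. Compound 2 gives > 10000 nM, again a limit and not a measured value. Both entries sit at the limit of > 10000 nM in this assay, at which 2 of the 2 values shown sit, so the two compounds cannot be separated on the numbers shown. Compound 3 `Clc1ccc(-c2n[nH]c3c2CCNCC3)cc1` differs from compound 2 by chloro in place of methyl on an aromatic carbon. Among the measured compounds shown here, no measured pair in this assay shows what such a change does on this core. With compound 2 known only as a limit, the step from compound 2 to compound 3 is expected to be a step that the limit leaves unreadable from compound 2 to compound 3, which amounts to no change beyond the scatter. Compound 3 is expected to give an inhibition constant around 15000 nM, in the range 5000 nM to 50000 nM, with a high chance that this assay again returns only a limit.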

Compound 3, inhibition constant: > 10000 nM
Compound 3 gave a limit, no number (the forecaster's own chance of this, stated with the estimate: 80%); the middle value does not contradict the limit.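

Among the compounds shown here, compound 3, like compound 2, returns only a limit in this assay, so no step from compound 2 to compound 3 can be read: the limit of > 10000 nM in this assay, at which 3 of the 3 values shown sit. The compounds shown leave open what chloro in place of methyl does on the shared core, and how strongly any of the three binds.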